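A few compounds are considered here, and "the series" means these few. Any claim that something is new, unique, unknown or untested is made for them only; others in the source may bear on it.

Measured so far: compound 1 `Cc1cnc(Nc2ccc(S(C)(=O)=O)cc2)nc1Nc1nc2ccccc2s1`, compound 2 `Cc1cnc(Nc2ccc([N+](=O)[O-])cc2)nc1Nc1nc2ccccc2s1`.

In a functional assay on MCF7 cells (Homo sapiens) for antiproliferative activity, read by MTT assay, with a stated time of 48 h (on this read-out higher numbers stand for weaker inhibition and lower numbers for stronger inhibition), compound 1 gives 6550 nM. For compound 2 the assay reports only a limit, > 50000 nM; its value sits at the limit of > 50000 nM in this assay, at which 1 of the 2 values shown sits, and is no number. The step of an at least 7.6-fold higher number from compound 1 to compound 2 (0.88 log units; beyond the scatter) is the only measured one, and it concerns the nitro group rather than the change now in hand. Compound 3 `Cc1cnc(Nc2cccc(F)c2)nc1Nc1nc2ccccc2s1` differs from compound 2 by 3-fluorophenyl in place of 4-nitrophenyl on a nitrogen on an aromatic ring. For the measured compounds named here, no measured step bears on this change. Compound 3 is expected to give 20000 nM (range 3000 nM to 50000 nM), a step of an at least 2.5-fold lower number from compound 2 to compound 3 (0.39 log units; beyond the scatter).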

Compound 3, half-maximal inhibitory concentration: > 50000 nM
Compound 3: no number, only a limit; the forecaster's own chance of this, stated with the estimate: 35%; middle value at least 2.5-fold (0.39 log units) from the limit.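

Compound 2 and compound 3 both give only a limit, not a number, so no step can be read between them: the limit of > 50000 nM in this assay, at which 2 of the 3 values shown sit. Going by these compounds, how 3-fluorophenyl compares with 4-nitrophenyl on a nitrogen on an aromatic ring remains open.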